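From Chlorophenyl to Difluorophenyl on the Shared Core

The source may hold more compounds than are shown below. What is called first, only, known or untested is meant among the compounds shown, and "the series" means these compounds.

Compound 3 `COc1cc2c(Oc3ccc(NC(=O)c4nn(-c5ccc(Cl)cc5)c(=O)cc4C)cc3F)ccnc2cc1OCCCN1CCCC1` gives 360 nM in a functional assay on NCI-H460 cells (Homo sapiens) for inhibition, read by MTT assay, with a stated time of 72 h (a lower number here means a stronger inhibitor, a higher number a weaker inhibitor), the second highest of the three numbers: it sits near compound 2 `COc1cc2c(Oc3ccc(NC(=O)c4nn(-c5ccccc5OC(F)(F)F)c(=O)cc4C)cc3F)ccnc2cc1OCCCN1CCCC1`, which gives 210 nM, and well apart from compound 1 `COc1cc2c(Oc3ccc(NC(=O)c4nn(-c5ccccc5C)c(=O)cc4C)cc3F)ccnc2cc1OCCCN1CCCC1`, which gives 1590 nM. Compound 4 `COc1cc2c(Oc3ccc(NC(=O)c4nn(-c5ccc(F)c(F)c5)c(=O)cc4C)cc3F)ccnc2cc1OCCCN1CCCC1` differs from compound 3 by 3,4-difluorophenyl in place of 4-chlorophenyl on an aromatic nitrogen. Among the measured compounds shown here, two measured steps bear on this site of the shared core: a 4.4-fold lower number from compound 1 to compound 3 (0.65 log units; beyond the scatter), and a 1.7-fold higher number from compound 2 to compound 3 (0.23 log units; within the scatter). The two aryl groups with a substituent in the fourth position, in compound 2 and compound 3, lie within the scatter of each other, and the change here keeps that pattern, so the expected step of a 1.1-fold higher number from compound 3 to compound 4 (0.05 log units; within the scatter) is none beyond the scatter. Compound 4 is therefore estimated at 400 nM, with a range from 150 nM to 1100 nM.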

Compound 4, half-maximal inhibitory concentration: 170 nM
Compound 4: middle estimate off by 2.4-fold (0.37 log units), on the high side; the measured number falls inside the stated range.
By their numbers in this assay, from the lowest: compounds 4, 2 and 3 (each within the scatter of the next, the first and the last beyond it); then compound 1.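

In this assay the change from 4-chlorophenyl to 3,4-difluorophenyl on the aromatic nitrogen gives a 2.1-fold lower number from compound 3 to compound 4 (0.33 log units; beyond the scatter) and so shows that this position can separate two halogen-bearing phenyl groups beyond the scatter. The step of a 1.2-fold lower number from compound 2 to compound 4 (0.09 log units; within the scatter) leaves 3,4-difluorophenyl level with 2-(trifluoromethoxy)phenyl, while a 9.4-fold lower number from compound 1 to compound 4 (0.97 log units; beyond the scatter) sets it clearly apart from 2-methylphenyl. Nothing shown here gives a measured reason for these differences. The compounds shown leave open how a phenyl group carrying a single fluorine would compare, and whether an amine or a carboxylic acid on this phenyl ring would be tolerated.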